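Bombesin receptor subtype-3 agonists: moving the chlorine substituent

The source may report more compounds than this note shows. Statements on the series, on what has been measured and on what is new or still open speak of the compounds shown alone.

Measured compounds:
Compound 1, `CCCCc1cnc(C(Cc2ccc(-c3ccccc3C(=O)O)cc2)C(C)C)[nH]1`: 2240 nM
Compound 2, `CCC(C)(C)Cc1c[nH]c(CCc2ccc(-c3ccccc3C(=O)O)cc2)n1`: 9.6 nM
Compound 3, `O=C(O)c1ccccc1-c1ccc(CCc2ncc(Cc3ccc(Cl)cc3)[nH]2)cc1`: 102 nM

Three compounds sharing a biphenyl carboxylic acid fragment were tested in an in vitro functional assay on cells for agonist activity at Bombesin receptor subtype-3 (Mus musculus), read by luminescence and calcium flux; on this read-out higher numbers stand for an effect only at larger amounts of compound and lower numbers for an effect already at smaller amounts. Compound 2 gives 9.6 nM, compound 1 gives 2240 nM, and compound 3 gives 102 nM. Compound 3 thus stands second highest of the three numbers: its nearest neighbour is compound 2, whose number is lower by a margin beyond the scatter, while compound 1 lies furthest away with a higher number, again beyond the scatter.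

Compound 4, `O=C(O)c1ccccc1-c1ccc(CCc2ncc(Cc3cccc(Cl)c3)[nH]2)cc1`, has not yet been measured in this assay. It differs from compound 3 only in how the same atoms are joined: 3-chlorophenyl in place of 4-chlorophenyl on a saturated chain carbon bound to an aromatic carbon. Among the measured compounds shown here, no other pair among the measured compounds shows this kind of change, so there is no measured step to lean on. The estimate therefore rests on the size of the group, which is unchanged, and treats the step as small. The step from compound 3 to compound 4 is expected to be a 1.5-fold higher number from compound 3 to compound 4 (0.17 log units; within the scatter), a modest drift toward a higher number that may well stay within the scatter. Compound 4 is accordingly expected to give 150 nM, with a range from 50 nM to 500 nM.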

Compound 4, half-maximal effective concentration: 31 nM
The estimate for compound 4 lay 4.8-fold (0.68 log units) above the measured number; the measured number lies below the stated range.
By their numbers in this assay, from the lowest: compound 2; then compound 4; then compound 3; then compound 1.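

In this assay the move of the chlorine alone gives a 3.3-fold lower number from compound 3 to compound 4 (0.52 log units; beyond the scatter), so 3-chlorophenyl in place of 4-chlorophenyl on a saturated chain carbon bound to an aromatic carbon is a change this read-out registers, even though the heavy atoms and the ring of the group stay the same. Among the compounds shown here, the earlier compounds could not show this, as no two of them differed in one place; this pair gives the first step and shows that at this position the group's size alone does not settle the number, since where the chlorine sits on the ring counts as well. Nothing available here gives a reason for this step.

On these data alone, whether the 3-position is favoured for chlorine only or also for other groups stays open, for instance with 3-bromophenyl or 3-methoxyphenyl at the same place. Also open, as far as these compounds go, is whether the same move of the chlorine would give a step of similar size on the core of compound 1, which carries a different link to the biphenyl carboxylic acid fragment.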